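Removing the Nitro Group from an Aziridine Urea

The source may hold more compounds than are shown below. What is called first, only, known or untested is meant among the compounds shown, and "the series" means these compounds.

For the measured compounds named here, compound 2 `N#CC1CN1C(=O)Nc1ccc([N+](=O)[O-])cc1` holds the lower of the two numbers so far: in a functional assay on L1210 cells (Mus musculus) for inhibition, read by MTT assay (on this read-out lower numbers stand for stronger inhibition and higher numbers for weaker inhibition), compound 2 gives 2600 nM, while compound 1 `CCOC(=O)c1ccc(NC(=O)N2CC2C#N)cc1` gives 9700 nM. Going by the values given here, the one measured step, a 3.7-fold lower number from compound 1 to compound 2 (0.57 log units; beyond the scatter), swapped one para group for another, so it bears only loosely on a change to a bare hydrogen. Compound 3 `N#CC1CN1C(=O)Nc1ccccc1` differs from compound 2 by hydrogen in place of nitro on an aromatic carbon. Because compound 2 with its nitro gave 2600 nM, removal of that group in compound 3 is expected to raise the number modestly, a 2.3-fold higher number from compound 2 to compound 3 (0.36 log units; beyond the scatter). Compound 3 is thus estimated at 6000 nM, ranging from 2000 nM to 20000 nM.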

Compound 3, half-maximal inhibitory concentration: 11000 nM
For compound 3 the middle estimate is 1.8-fold (0.26 log units) below the measured one; the measured number falls inside the stated range.
By their numbers in this assay, from the lowest: compound 2; then compounds 1 and 3 (each within the scatter of the next).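

Removing the nitro gives a 4.2-fold higher number from compound 2 to compound 3 (0.63 log units; beyond the scatter) in this assay and so shows that, on this core, the nitro gives a lower number than a bare hydrogen. Replacing ethoxycarbonyl with hydrogen gives a 1.1-fold higher number from compound 1 to compound 3 (0.05 log units; within the scatter) and therefore separates neither group from the other in this assay. Of the three groups at this position, only the nitro stands apart.

Going by these compounds, whether an amine or a carboxylic acid here would match the nitro remains open. Nothing available explains why the nitro stands apart.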